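Extending a methyl to an aminoethoxy chain on a PP1D inhibitor

The compounds below may be only part of what the source reports. "The series", "measured", "known", "first", "only" and "open" are said of these compounds alone.

Three compounds from this series were examined in an assay on isolated protein for inhibition of protein phosphatase 1D (Homo sapiens), read by malachite green (a lower number here means a stronger inhibitor, a higher number a weaker inhibitor), which is an assay on the isolated human enzyme. Compound 1 `O=c1[nH]c2ccc(-c3csc(-c4ccc(F)c(C(F)(F)F)c4)n3)cc2o1` gives < 20000 nM in this assay, and that is a limit rather than a number. Compound 2 `CCc1cc(F)ccc1-c1nc(-c2ccc3[nH]c(=O)oc3c2)cs1` gives < 20000 nM in this assay, again only a limit. Compound 3 `Cc1cc(F)ccc1-c1nc(-c2ccc3c(c2)CC(=O)N3)cs1` gives < 20000 nM in this assay, once more a limit. Among the measured compounds shown here, all of the evidence at hand is therefore (the limit of < 20000 nM in this assay, at which 3 of the 3 values shown sit), so no measured step between two compounds can be drawn, and compound 2 stands only at that limit, with no number of its own.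

Compound 4 `NCCOCc1cc(F)ccc1-c1nc(-c2ccc3[nH]c(=O)oc3c2)cs1` is the next compound to be measured. It differs from compound 2 in one place: 2-aminoethoxy in place of methyl on a saturated chain carbon bound to an aromatic carbon. For the measured compounds named here, with only limits behind it, no step in this assay can be sized from data, so the step from compound 2 to compound 4 is expected to be small, a step that the limit leaves unreadable from compound 2 to compound 4, in no firm direction. Compound 4 is estimated to give about 6000 nM, with a range from 1000 nM to 20000 nM, and it may well again be reported only as a limit.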

Compound 4, half-maximal inhibitory concentration: < 20000 nM
Compound 4 ended at the assay's limit; the forecaster's own chance of this, stated with the estimate: 60%; the middle value is on the limit's open side.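

In this assay compound 4 gives < 20000 nM, which is a limit and not a number. Compound 2 also stands only at a limit, so no step can be read between compound 2 and compound 4. The compounds shown leave open what number any of them would give, and whether 2-aminoethoxy in place of methyl changes it.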